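The source may report more compounds than this note shows. Statements on the series, on what has been measured and on what is new or still open speak of the compounds shown alone.

Measured compounds and their values in an ADME assay on HEK293 cells (Homo sapiens) for cytotoxicity, read by CCK-8 assay and cell counting, with a stated time of 2 days; on this read-out higher numbers stand for weaker inhibition and lower numbers for stronger inhibition:
compound 1, `Oc1ccc(-c2cc(-c3ccsc3)nc(-c3cccc(Cl)c3)c2)cc1`, 2670 nM;
compound 2, `Oc1cccc(-c2cc(-c3cccc(Cl)c3)nc(-c3cccs3)c2)c1`, 3150 nM;
compound 3, `Oc1cccc(-c2cc(-c3ccsc3)nc(-c3ccccc3Cl)c2)c1`, 2720 nM.

The three numbers in this assay lie close together. Compound 3 gives the second highest of them, with compound 1 nearest and compound 2 furthest, and both of those gaps fall within the usual scatter, so no order among the three can be read from these data.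

Compound 4, `Oc1cccc(-c2cc(-c3ccsc3)nc(-c3cccc(Cl)c3)c2)c1`, differs from compound 3 in one place: 3-chlorophenyl in place of 2-chlorophenyl on an aromatic carbon. Within the data shown here, no step between two measured compounds that differ in the same way is available here. Given how tightly compounds 1, 2 and 3 sit in this assay, the step from compound 3 to compound 4 is expected to stay within the scatter, a 1.0-fold higher number from compound 3 to compound 4 (0.01 log units; within the scatter), in no particular direction. For compound 4 in this assay the estimate is 2800 nM, expected to fall between 1400 nM and 5600 nM.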

Compound 4, half-maximal inhibitory concentration: 3180 nM
Estimate against measurement, compound 4: 1.1-fold (0.06 log units) below; the range from low to high includes it.
By their numbers in this assay, from the lowest: compounds 1, 3, 2 and 4 (each within the scatter of the next).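

Compound 4 joins the three earlier compounds through single changes, and in this assay each step stays within the scatter: 3-chlorophenyl in place of 2-chlorophenyl (a 1.2-fold higher number from compound 3 to compound 4 (0.07 log units; within the scatter)), thiophen-3-yl in place of thiophen-2-yl (a 1.0-fold higher number from compound 2 to compound 4 (0.00 log units; within the scatter)) and 3-hydroxyphenyl in place of 4-hydroxyphenyl (a 1.2-fold higher number from compound 1 to compound 4 (0.08 log units; within the scatter)). On the carbon next to the ring nitrogen, the two chlorophenyl groups therefore cannot be told apart in this read-out.

As far as these compounds go, whether an amine or a carboxylic acid in place of the chlorine would shift the number remains open. Nothing shown bears on why these steps are so small.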